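Series notes: phenyl to 3-(trifluoromethyl)phenyl on the triazole

The compounds below may be only part of what the source reports. "The series", "measured", "known", "first", "only" and "open" are said of these compounds alone.

Compound 2 `C/C(=C\CC/C(C)=C/CC[C@@H]1[C@@]2(C)CCC(=O)C(C)(C)[C@H]2CC[C@@]1(C)O)CC/C=C(\C)C(=O)OCc1cn(-c2ccccc2)nn1` carries an unsubstituted phenyl. In a functional assay on A549 cells (Homo sapiens) for antiproliferative activity, read by MTT assay, with a stated time of 48 h (a higher number here means a weaker inhibitor, a lower number a stronger inhibitor), compound 2 gives > 150000 nM, a limit of the assay rather than a number. Compound 1 `C/C(=C\CC/C(C)=C/CC[C@@H]1[C@@]2(C)CCC(=O)C(C)(C)[C@H]2CC[C@@]1(C)O)CC/C=C(\C)C(=O)OCc1cn(-c2ccc(C(F)(F)F)cc2)nn1`, with 4-(trifluoromethyl)phenyl, also sits at a limit. In this assay compound 1 gives > 150000 nM, again only a limit. Within the data shown here, compound 3 `C/C(=C\CC/C(C)=C/CC[C@@H]1[C@@]2(C)CCC(=O)C(C)(C)[C@H]2CC[C@@]1(C)O)CC/C=C(\C)C(=O)OCc1cn(-c2cccc(Cl)c2)nn1`, with 3-chlorophenyl, is the one compound with a number: in this assay compound 3 gives 147000 nM. Because the limit of > 150000 nM in this assay, at which 2 of the 3 values shown sit, the step that the two limits leave unreadable from compound 1 to compound 2 cannot be read, while the steps of an at least 1.0-fold lower number from compound 2 to compound 3 (0.00 log units; that floor lies within the scatter) and an at least 1.0-fold lower number from compound 1 to compound 3 (0.00 log units; that floor lies within the scatter) sit at their floor, within scatter. Compound 4 `C/C(=C\CC/C(C)=C/CC[C@@H]1[C@@]2(C)CCC(=O)C(C)(C)[C@H]2CC[C@@]1(C)O)CC/C=C(\C)C(=O)OCc1cn(-c2cccc(C(F)(F)F)c2)nn1` differs from compound 2 by trifluoromethyl in place of hydrogen on an aromatic carbon. Among the measured compounds shown here, no measured step moves beyond scatter, so none is expected here. The step expected is a number no higher from compound 2 to compound 4 (the limit leaves the size open). Compound 4 is estimated at 150000 nM, between 90000 nM and 300000 nM, most likely reported as a limit again.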

Compound 4, half-maximal inhibitory concentration: > 150000 nM
Compound 4: only a limit was reported; the forecaster's own chance of this, stated with the estimate: 70%; the middle value lies on the limit itself.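

In this assay, compound 4 is reported only as a limit, so trifluoromethyl in this new place on the phenyl gives no readable value, the same outcome as the 4-(trifluoromethyl)phenyl of compound 1. Trifluoromethyl in place of chloro gives an at least 1.0-fold higher number from compound 3 to compound 4 (0.00 log units; that floor lies within the scatter), so the one numbered compound stays unseparated from compound 4. The steps to compound 4 from compound 2 and from compound 1 cannot be read, because both ends of each are limits: the limit of > 150000 nM in this assay, at which 3 of the 4 values shown sit.

Still open, as far as these compounds go, is whether an amine or a carboxylic acid on this phenyl, or a longer chain in its place, would give a value clearly under the limit.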